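Compound 3 and a pyrrolidin-1-yl chain end

This account rests on a few compounds, and the source may have more. Where it says the series, first, only, none or still open, it means among the compounds named here.

Of the compounds shown here, three that share one core have been measured in an in vitro ADME assay on microsomes from liver (Homo sapiens) for metabolic stability, read by LC-MS; on this read-out higher numbers stand for a longer-lived compound and lower numbers for a shorter-lived compound. Compound 1, `C=CCON/C(=N\C1=NC(=O)C(=O)N1C(C)C)Nc1ccc(Cl)c(Cl)c1`, gives > 1 h, which is a limit of the assay and not a number. Compound 2, `CC(C)N1C(=O)C(=O)N=C1/N=C(\NOCc1ccccc1)Nc1ccc(Cl)c(Cl)c1`, gives 0.215 h, and compound 3, `CCCCCCN/C(=N\C1=NC(=O)C(=O)N1C(C)C)Nc1ccc(Cl)c(Cl)c1`, gives 0.131 h. These last two lie within the scatter of each other, as a 1.6-fold lower number from compound 2 to compound 3 (0.22 log units; within the scatter) shows, so compound 3 shares the short-lived end of the numbers with compound 2.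

Compound 4, `CC(C)N1C(=O)C(=O)N=C1/N=C(\NCCCCN1CCCC1)Nc1ccc(Cl)c(Cl)c1`, differs from compound 3 by one change: pyrrolidin-1-yl in place of ethyl on a saturated chain carbon, four bonds along the chain from an amine nitrogen. Pyrrolidin-1-yl stands in place of ethyl on a saturated chain carbon, four bonds along the chain from an amine nitrogen. For the measured compounds named here, no measured compound carries this group, so the evidence is indirect. The measured steps all alter the substituent on that same amine nitrogen. They are an at least 4.6-fold lower number from compound 1 to compound 2 (0.66 log units; beyond the scatter) and an at least 7.6-fold lower number from compound 1 to compound 3 (0.88 log units; beyond the scatter), both beyond the scatter, while the step between compound 2 and compound 3 is not. The value of compound 3, 0.131 h, sits low, and an at least 7.6-fold lower number from compound 1 to compound 3 (0.88 log units; beyond the scatter) shows how far this substituent can move the number, so a modest rise is expected rather than a fall. The expected change is a 2.3-fold higher number from compound 3 to compound 4 (0.36 log units; beyond the scatter). For compound 4 the estimated half-life is 0.3 h, with an expected range of 0.1 h to 0.9 h.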

Compound 4, half-life: > 1 h
Compound 4 was reported as a limit; the forecaster's own chance of this, stated with the estimate: 10%; middle value at least 3.3-fold (0.52 log units) from the limit.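

In this assay, for the compounds shown here, the earlier compounds had linked a long half-life on this amine nitrogen to allyloxy alone, while the hexyl chain stood at the short-lived end. Pyrrolidin-1-yl, placed on a saturated chain carbon, four bonds along the chain from an amine nitrogen, breaks that link, with an at least 7.6-fold higher number from compound 3 to compound 4 (0.88 log units; beyond the scatter), so a long chain on this nitrogen need not go with a short half-life once its end is changed. The 4-(pyrrolidin-1-yl)butyl group also stands apart from benzyloxy, with an at least 4.6-fold higher number from compound 2 to compound 4 (0.66 log units; beyond the scatter), while the step involving compound 1 cannot be read, since both of its values are limits: the limit of > 1 h in this assay, at which 2 of the 4 values shown sit.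

From the compounds shown here alone, how far compound 4 lies past its limit stays open, as does whether the step follows the ring or the nitrogen alone. A piperidine or a morpholine at the same chain end, an open-chain dimethylamine, or a shorter chain carrying the same pyrrolidin-1-yl would separate these possibilities.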